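Pyrrolidine Sulfone Exchanged for Azepane on Saturated Ring

The compounds below may be only part of what the source reports. "The series", "measured", "known", "first", "only" and "open" are said of these compounds alone.

Compound 1 `Cc1nn([C@H](C)c2ccc(Cl)cc2Cl)c2nc(N3CC[C@H](N4CCC[C@H]4CCS(C)(=O)=O)[C@H](C)C3)cnc12` carries a 2-(2-(methylsulfonyl)ethyl)pyrrolidin-1-yl group on its saturated six-membered ring, yet no number has been recorded for it in an assay on CCRF-CEM cells for antagonist activity at C-C chemokine receptor type 4 (Homo sapiens), read by CellTiter-Glo, with stated times of 30 min and 60 min, in the presence of a further agent that is not named here; on this read-out lower numbers stand for stronger inhibition and higher numbers for weaker inhibition; its entry there reads "not determined" (no result reported). Among the compounds with values here, the only measured relative is compound 2 `Cc1nn([C@H](C)c2ccc(Cl)cc2Cl)c2nc(C3=CC[C@H](N4CCC[C@H]4CO)[C@H](C)C3)cnc12`, which differs from compound 1 in more than one place; in this assay compound 2 gives 179 nM. Compound 3 `Cc1nn([C@H](C)c2ccc(Cl)cc2Cl)c2nc(N3CC[C@H](N4CCCCCC4)[C@H](C)C3)cnc12` is reached from compound 1 by a single change, azepan-1-yl in place of 2-(2-(methylsulfonyl)ethyl)pyrrolidin-1-yl on a saturated ring carbon. Within the data shown here, no measured pair shows a change of this kind, so neither the size nor the direction of the step in this assay can be read from the data; the value of compound 2 gives the only scale of potency. Compound 3 is expected to give about 300 nM in this assay, with a range from 60 nM to 2000 nM.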

Compound 3, half-maximal inhibitory concentration: 195 nM
Compound 3: the middle estimate sits 1.5-fold (0.19 log units) above what was measured, within the range that was stated.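

In this assay, within the data shown here, compound 1 stands as "not determined" (no result reported), and no step from it to compound 3 can be read. The compounds shown leave open how azepan-1-yl compares with 2-(2-(methylsulfonyl)ethyl)pyrrolidin-1-yl at this place. Nothing given here bears on the value of compound 3.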